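The source may report more compounds than this note shows. Statements on the series, on what has been measured and on what is new or still open speak of the compounds shown alone.

Compound 1 `CCN(C(=O)c1cc(C(C)C)c(O)cc1O)c1ccc(NC(=O)CCCCCCC(=O)NO)cc1`: 5630 nM
Compound 2 `CC(C)c1cc(C(=O)Nc2cccc(NC(=O)CCCCCCC(=O)NO)c2)c(O)cc1O`: > 10000 nM
Compound 3 `CC(C)c1cc(C(=O)Nc2ccccc2NC(=O)CCCCCCC(=O)NO)c(O)cc1O`: > 10000 nM

In a functional assay on A549 cells (Homo sapiens) for inhibition, read by sulforhodamine B assay, with a stated time of 48 h (on this read-out lower numbers stand for stronger inhibition of growth and higher numbers for weaker inhibition of growth), compound 2 gives > 10000 nM, which is a limit of the assay and not a number. Compound 3 gives > 10000 nM, also a limit. The pair share this position: the limit of > 10000 nM in this assay, at which 2 of the 3 values shown sit. Only compound 1 has a true number, 5630 nM.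

Compound 4 `CC(C)c1cc(C(=O)N(C)c2cccc(NC(=O)CCCCCCC(=O)NO)c2)c(O)cc1O` has methyl in place of hydrogen on an amide-type nitrogen of compound 2 (methyl in place of hydrogen on an amide-type nitrogen). Compound 1, with 5630 nM, also lacks the amide hydrogen, though it differs in other ways too, so only a small gain in inhibition is expected. The expected change is an at least 1.2-fold lower number from compound 2 to compound 4 (0.09 log units; that floor lies within the scatter). For compound 4 the estimated value is 8000 nM, with an expected range of 3000 nM to 20000 nM.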

Compound 4, concentration for 50% growth inhibition: 2300 nM
Estimate against measurement, compound 4: 3.5-fold (0.54 log units) above, and the stated range ends above it.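

In this assay, methyl in place of hydrogen on the amide-type nitrogen gives an at least 4.3-fold lower number from compound 2 to compound 4 (0.63 log units; beyond the scatter). Within the data shown here, this is the first sign that this nitrogen need not keep its amide hydrogen, and that this one small change is enough to bring a compound from the limit to a true number. The starting point of the step is a limit and not a number: the limit of > 10000 nM in this assay, at which 2 of the 4 values shown sit.

From the compounds shown here alone, whether a propyl group or a chain ending in an amine on this nitrogen would lower the number further remains open. So does whether the same methyl would have a similar effect in compound 3.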